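The source may hold more compounds than are shown below. What is called first, only, known or untested is meant among the compounds shown, and "the series" means these compounds.

In a functional assay on MIA PaCa-2 cells (Homo sapiens) for inhibition, read by MTT assay, with a stated time of 48 h, tested at 10 uM (a lower number here means less inhibition of growth, a higher number more inhibition of growth at the concentration tested), compound 3 `O=C(/C=C/c1ccc(OCc2cn(Cc3cccc(Br)c3)nn2)cc1)c1ccc(Br)cc1` gives 43%. Compound 2 `O=C(/C=C/c1ccc(OCc2cn(Cc3ccccc3Br)nn2)cc1)c1ccc(Br)cc1` gives 43% in this assay, and the two stand level at the digits shown; together they are the highest of the three numbers measured, but compound 1 `C#CCOc1ccc(/C=C/C(=O)c2ccc([N+](=O)[O-])cc2)cc1`, with 42% in this assay, sits only a hair lower and within the scatter of both. Among the measured compounds shown here, the one step that can be traced between measured compounds, no change at the digits printed from compound 2 to compound 3 (within the scatter), moved the bromine on the benzyl ring from one position to another and left the number where it was.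

Compound 4 `O=C(/C=C/c1ccc(OCc2cn(Cc3cccc(F)c3)nn2)cc1)c1ccc(Br)cc1` differs from compound 3 in a single spot: fluoro in place of bromo on an aromatic carbon, so that a 3-bromophenyl becomes a 3-fluorophenyl on the benzyl group carried by the triazole. For the measured compounds named here, no measured pair shows a bromine exchanged for a fluorine, so the only guide is that the same benzyl ring tolerated a shift of its bromine without any change in this assay. On that basis the step of a number 1 percentage points lower from compound 3 to compound 4 (within the scatter) is expected to stay within the scatter, in no particular direction. Compound 4 is therefore estimated to give 42% in this assay, with a likely range from 30% to 54%.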

Compound 4, percent growth inhibition at one concentration: 34%
For compound 4 the middle estimate is 8 percentage points above the measured one; measured number inside the range.
By their numbers in this assay, from the lowest: compounds 4, 1, 2 and 3 (each within the scatter of the next).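

In this assay, among the compounds shown here, the first exchange of one halogen for another on this benzyl ring gives a number 9 percentage points lower from compound 3 to compound 4 (within the scatter), and the comparison with the other bromine position gives a number 9 percentage points lower from compound 2 to compound 4 (within the scatter). Until now only a shift of the bromine had been seen, whereas these steps show that 3-fluorobenzyl can stand in place of either bromobenzyl group without a change that can be told from the usual spread of repeated measurements, so compounds 2, 3 and 4 cannot be separated at the single concentration tested. Nothing available explains these numbers or connects them to any property of bromo or fluoro.

Going by these compounds, all the groups compared at this position are halogens, so it remains open whether the number would hold with a group of another kind on the ring, such as an amine, a carboxylic acid or a longer chain, or with no group there at all. The bromine on the other aromatic ring is the same in compounds 2, 3 and 4, so these steps say nothing about its contribution.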